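Trifluoromethylphenyl in Place of Dichlorophenyl on a Weak Nucleoside

A few compounds are considered here, and "the series" means these few. Any claim that something is new, unique, unknown or untested is made for them only; others in the source may bear on it.

Compound 1 `OC[C@H]1O[C@@H](n2cnc3c(NCc4ccc(Cl)cc4Cl)ncnc32)[C@H](O)[C@@H]1O`: in a functional assay on K562 cells (Homo sapiens) for antiproliferative activity, with a stated time of 72 h (on this read-out higher numbers stand for weaker inhibition and lower numbers for stronger inhibition), compound 1 gives 106000 nM.
Compound 2 `COc1cc(CNc2ncnc3c2ncn3[C@@H]2O[C@H](CO)[C@@H](O)[C@H]2O)cc(OC)c1`: in this assay compound 2 reaches only a limit of the assay, > 166000 nM.
Compound 3 `COc1cc(O)cc(OC)c1CNc1ncnc2c1ncn2[C@@H]1O[C@H](CO)[C@@H](O)[C@H]1O`: in this assay compound 3 likewise reaches only a limit of the assay, > 166000 nM.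

Going by the values given here, compound 1 is therefore the only member of the set with an actual number in this assay; the other two values are limits, both sitting at the limit of > 166000 nM in this assay, at which 2 of the 3 values shown sit. Among the compounds with values here, the one measured step that changes the aryl group on the saturated chain carbon is an at least 1.5-fold higher number from compound 1 to compound 2 (0.19 log units; that floor lies within the scatter), and its floor lies within the usual scatter, so it shows nothing more than that compound 2 is not stronger than compound 1.

Compound 4 `OC[C@H]1O[C@@H](n2cnc3c(NCc4cccc(C(F)(F)F)c4)ncnc32)[C@H](O)[C@@H]1O` differs from compound 1 by 3-(trifluoromethyl)phenyl in place of 2,4-dichlorophenyl on a saturated chain carbon bound to a nitrogen on an aromatic ring. Within the data shown here, this is another exchange of the aryl group at the same place, and the only comparable step, from compound 1 to compound 2, gave at most a modest weakening that cannot be told from scatter. Compound 4 is therefore expected to stay close to compound 1, with the step of a 1.2-fold higher number from compound 1 to compound 4 (0.07 log units; within the scatter) expected to fall within or only slightly beyond the scatter, in the direction of weaker inhibition if anything. Compound 4 is estimated at 125000 nM, with a range from 45000 nM to 330000 nM, and a fair chance that the assay reports only a limit.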

Compound 4, half-maximal inhibitory concentration: > 166000 nM
Compound 4: no number, only a limit (the forecaster's own chance of this, stated with the estimate: 40%); middle value at least 1.3-fold (0.12 log units) away from the limit.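

In this assay, 3-(trifluoromethyl)phenyl in place of 2,4-dichlorophenyl gives an at least 1.5-fold higher number from compound 1 to compound 4 (0.19 log units; that floor lies within the scatter), so a second kind of aryl group at this place also fails to bring a number stronger than that of compound 1, although the floor of this step does not establish a real weakening. The limit is thus no longer confined to the methoxy-bearing aryl groups of compound 2 and compound 3, as it now also appears with a trifluoromethyl-bearing one, while the step between compound 2 and compound 4 cannot be read, both values being limits. Compound 1 remains the only member of the set with an actual number, and the other three compounds share a single ceiling: the limit of > 166000 nM in this assay, at which 3 of the 4 values shown sit.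

On these data alone, how far compound 2, compound 3 and compound 4 lie beyond that ceiling remains open, and so does whether they differ from one another at all. Also open, as far as these compounds go, is whether an aryl group carrying an amine or a carboxylic acid, or a longer chain on the nitrogen, would give a clearly stronger number than compound 1 on the shared core.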